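This account rests on a few compounds, and the source may have more. Where it says the series, first, only, none or still open, it means among the compounds named here.

Measured in a functional assay on HCT-116 cells (Homo sapiens) for inhibition, read by CCK-8 assay, with a stated time of 72 h, tested at 8 uM; on this read-out higher numbers stand for more inhibition of growth at the one concentration tested and lower numbers for less inhibition of growth:
- compound 1 `COc1ccc(SCc2ccc(C(=O)Nc3ccccc3N)cc2)cc1`: 90.1%
- compound 2 `Nc1ccccc1NC(=O)c1ccc(CSc2ccc(Br)cc2)cc1`: 67.7%
- compound 3 `CC(C)(C)c1ccc(SCc2ccc(C(=O)Nc3ccccc3N)cc2)cc1`: 60.5%

Compound 2 stands well under compound 1 and within the scatter of compound 3. Compound 4 `Cc1cc(C)cc(SCc2ccc(C(=O)Nc3ccccc3N)cc2)c1` has 3,5-dimethylphenyl in place of 4-bromophenyl on a sulfur. Among the measured compounds shown here, no measured step tests this group directly. The closest guide is a number 7.2 percentage points lower from compound 2 to compound 3 (within the scatter), which stayed within the scatter. The larger steps, a number 22.4 percentage points lower from compound 1 to compound 2 (beyond the scatter) and a number 29.6 percentage points lower from compound 1 to compound 3 (beyond the scatter), both start from the methoxy group of compound 1, which this change does not involve. The expected step is therefore none beyond the scatter, namely a number 1.7 percentage points lower from compound 2 to compound 4 (within the scatter). For compound 4 the estimated value is 66%, with an expected range of 47% to 85%.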

Compound 4, percent growth inhibition at one concentration: 72.9%
For compound 4 the middle estimate is 6.9 percentage points below the measured one; low and high end bracket the measured number.
By their numbers in this assay, from the lowest: compounds 3, 2 and 4 (each within the scatter of the next, the first and the last beyond it); then compound 1.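

On the sulfur, 3,5-dimethylphenyl can replace 4-bromophenyl without a change beyond the scatter in this assay, with a number 5.2 percentage points higher from compound 2 to compound 4 (within the scatter), so this first ring with two substituents stays level with compound 2. Against 4-methoxyphenyl the same group still gives a number 17.2 percentage points lower from compound 1 to compound 4 (beyond the scatter), which leaves compound 1 set apart from the other three compounds. Nothing available explains these differences.

The compounds shown leave open whether the value of compound 1 depends on the methoxy group itself. As far as these compounds go, how a phenyl ring bearing a hydroxy group, an amine or a carboxylic acid would read also remains open.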